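The source may report more compounds than this note shows. Statements on the series, on what has been measured and on what is new or still open speak of the compounds shown alone.

Compound 1 `CS(=O)(=O)c1ccc(C(=O)NCCC(=O)N2CCCCC2)cc1[N+](=O)[O-]` is the smaller member of the set. In an assay on isolated protein for inhibition of thyroid hormone receptor alpha (Homo sapiens), read by fluorescence polarization (on this read-out higher numbers stand for weaker inhibition and lower numbers for stronger inhibition), compound 1 reaches only the limit of the assay, > 60000 nM, and gives no number. Compound 2 `CS(=O)(=O)c1ccc(C(=O)NCCCC(=O)N2CCC(c3ccccc3)CC2)cc1[N+](=O)[O-]` carries a longer chain and a phenyl on the saturated ring at its end. In this assay compound 2 likewise reaches only a limit, > 60000 nM, and not a measured number. Where compound 2 stands is therefore fixed only as a limit, and the one other value shown is a limit too, since both sit at the limit of > 60000 nM in this assay, at which 2 of the 2 values shown sit. Going by the values given here, no step between measured compounds can be drawn from this pair. Compound 3 `CS(=O)(=O)c1ccc(C(=O)NCCCC(=O)N2CCCCC2)cc1[N+](=O)[O-]` is reached from compound 2 by hydrogen in place of phenyl on a saturated ring carbon. Compound 3 thus matches compound 1 in all but chain length. With both measured neighbours sitting at the limit, no step beyond the scatter is expected in this assay. The expected step from compound 2 to compound 3 is a step that the limit leaves unreadable from compound 2 to compound 3. Compound 3 is estimated at 80000 nM in this assay, most likely reported only as a limit, within a range from 40000 nM to 200000 nM.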

Compound 3, half-maximal inhibitory concentration: > 60000 nM
Compound 3: no number, only a limit (the forecaster's own chance of this, stated with the estimate: 90%); the middle value is on the limit's open side.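

Compound 3 also gives only a limit in this assay, so neither the step from compound 2 to compound 3 nor the step from compound 1 to compound 3 can be read: the limit of > 60000 nM in this assay, at which 3 of the 3 values shown sit. The compounds shown leave open how strongly any of the three inhibits, and whether chain length or the phenyl makes any difference in this assay.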